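The source may hold more compounds than are shown below. What is called first, only, known or untested is meant among the compounds shown, and "the series" means these compounds.

Measured so far in a functional assay, with a stated time of 10 min (on this read-out higher numbers stand for weaker inhibition and lower numbers for stronger inhibition), for the series:
- compound 1 `CCCCCCCCCCCCOc1cc(OC)c(Br)cc1C(C)=O` gives 23100000 nM
- compound 2 `CCCCCCCCCCCCCCOc1cc(OC)c(Br)cc1C(C)=O` gives 13200000 nM
- compound 3 `CCCCCCCCCCCCCCCCOc1cc(OC)c(Br)cc1C(C)=O` gives 100000 nM

Compound 1 stands at the weak end of these numbers, and its nearest step (a 1.8-fold lower number from compound 1 to compound 2 (0.24 log units; within the scatter)) stays within the scatter. The large steps are a 230-fold lower number from compound 1 to compound 3 (2.36 log units; beyond the scatter) and a 130-fold lower number from compound 2 to compound 3 (2.12 log units; beyond the scatter) and both are changes in the saturated chain.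

Compound 4 `CCCCCCCCCCCCOc1cc(OC)ccc1C(C)=O` keeps the chain of compound 1 and changes the ring instead, with hydrogen in place of bromo on an aromatic carbon as the only difference. Within the data shown here, all three measured compounds carry the bromo group, so no measured step bears directly on this change, and the large chain steps cannot be carried over to it. With no such comparison in the data, no step beyond the scatter is expected in this assay and no direction is favoured, though the uncertainty is wide. The estimated step is a 1.2-fold lower number from compound 1 to compound 4 (0.06 log units; within the scatter) and it leaves the expectation close to compound 1 (23100000 nM). For compound 4 the estimated value is 20000000 nM with an expected range of 3000000 nM to 80000000 nM in this series.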

Compound 4, half-maximal inhibitory concentration: 65600000 nM
Estimate against measurement, compound 4: 3.3-fold (0.52 log units) below; the range from low to high includes it.
By their numbers in this assay, from the lowest: compound 3; then compounds 2 and 1 (each within the scatter of the next); then compound 4.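

In this assay, hydrogen in place of bromo, on the aromatic carbon ortho to a methoxy group and meta to an acetyl group, gives a 2.8-fold higher number from compound 1 to compound 4 (0.45 log units; beyond the scatter) on the same chain, so this ring position registers in the read-out and the bromo compound lies on the stronger side. This modest ring step is still much smaller than the chain step, a 230-fold lower number from compound 1 to compound 3 (2.36 log units; beyond the scatter), so the largest change in this set remains the one in the chain. No measurement shown accounts for the effect of the bromo group at this position.

The compounds shown leave open whether chlorine or a nitrile on this carbon would read closer to bromo or to hydrogen. They also leave open whether the bromo step keeps its size on the longer chain of compound 3.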